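Amide substituent change in the vitamin D3 receptor series

The compounds below may be only part of what the source reports. "The series", "measured", "known", "first", "only" and "open" are said of these compounds alone.

Three compounds of the series have a number in an assay on cells for agonist activity at vitamin D3 receptor (Homo sapiens), read by microscopy; on this read-out lower numbers stand for an effect already at smaller amounts and higher numbers for an effect only at larger amounts of compound. Compound 1 `CCn1c(C(=O)NCC(=O)O)ccc1C(CC)(CC)c1ccc(C#CC(O)(CC)CC)c(C)c1` gives 9.36 nM, compound 2 `CCn1c(C(=O)N[C@H](C(=O)O)C(C)C)ccc1C(CC)(CC)c1ccc(C#CC(O)(CC)CC)c(C)c1` gives 17.7 nM and compound 3 `CCn1cc(C(CC)(CC)c2ccc(C#CC(O)(CC)CC)c(C)c2)cc1C(=O)NCCN(C)C` gives 19.3 nM. Compound 3 stands highest of the three; against compound 2 the gap is within the scatter, against compound 1 it is beyond the scatter. Compound 4 `CCn1cc(C(CC)(CC)c2ccc(C#CC(O)(CC)CC)c(C)c2)cc1C(=O)N[C@@H](C)CO` differs from compound 3 in one place: 1-(hydroxymethyl)ethyl in place of 2-(dimethylamino)ethyl on an amide-type nitrogen.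

Among the compounds with values here, the only measured step that bears on a change at the amide substituent is a 1.9-fold higher number from compound 1 to compound 2 (0.28 log units; within the scatter). That step adds a branched group on the carbon bound to the amide-type nitrogen and leaves the number within the scatter. Within the data shown here, no measured step exchanges a dimethylamino group for a hydroxyl group, and no step starts from compound 3, so the expectation for compound 4 rests on the one step at the amide substituent and on the spread of the three numbers, which all lie close together.

Taken together, for compound 4 in this assay a step of about a 1.2-fold lower number from compound 3 to compound 4 (0.08 log units; within the scatter) is expected, in either direction, not beyond the scatter. The estimate for compound 4 is 16 nM, with a range from 5 nM to 50 nM.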

Compound 4, half-maximal effective concentration: 7.33 nM
Compound 4: the middle estimate sits 2.2-fold (0.34 log units) above what was measured, and the stated range covers the measured number.
By their numbers in this assay, from the lowest: compounds 4, 1, 2 and 3 (each within the scatter of the next, the first and the last beyond it).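

In this assay, within the data shown here, the substituent on the amide-type nitrogen now gives a step beyond the scatter: 1-(hydroxymethyl)ethyl in place of 2-(dimethylamino)ethyl gives a 2.6-fold lower number from compound 3 to compound 4 (0.42 log units; beyond the scatter), a modest step, while the only earlier step at this kind of place, a 1.9-fold higher number from compound 1 to compound 2 (0.28 log units; within the scatter), stayed within it. The position therefore responds to the exchange of one open-chain substituent for another, although this rests on a single pair. The exchange removes the dimethylamino group and brings in a hydroxyl group, a hydrogen-bond donor and a defined stereocentre all at once, and no information here bears on which of these accounts for the step.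

A 2-hydroxyethyl group on the same nitrogen would separate the hydroxyl group from the methyl branch, and the mirror-image form of 1-(hydroxymethyl)ethyl would isolate the stereocentre. On these data alone, how a carboxylic acid or a longer hydroxyalkyl chain at this nitrogen would read on the core of compound 4 also stays open.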